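The compounds below may be only part of what the source reports. "The series", "measured", "known", "first", "only" and "open" are said of these compounds alone.

Series notes. Compound 1 `COc1cc2c(Oc3ccc(NC(=O)c4cn(-c5ccccc5)nn4)cc3F)ccnc2cc1OCCCN1CCCC1` gives 180 nM in a functional assay on HT-29 cells (Homo sapiens) for cytotoxicity, read by MTT assay, with a stated time of 72 h; a lower number here means a stronger inhibitor, a higher number a weaker inhibitor. Compound 2 `COc1cc2c(Oc3ccc(NC(=O)c4cn(-c5ccccc5C)nn4)cc3F)ccnc2cc1OCCCN1CCCC1` carries methyl in place of hydrogen on an aromatic carbon and gives 1200 nM in this assay, so a 6.7-fold higher number from compound 1 to compound 2 (0.82 log units; beyond the scatter). Compound 3 `COc1cc2c(Oc3ccc(NC(=O)c4cn(-c5ccccc5C)nn4)cc3F)ccnc2cc1OCCCN1CCN(C)CC1` gives 1430 nM in this assay, and a 1.2-fold higher number from compound 2 to compound 3 (0.08 log units; within the scatter). The difference between the core of compound 1 and the core of compound 3 is not broken down here. Compound 4 `COc1cc2c(Oc3ccc(NC(=O)c4cn(-c5c(C)cccc5C)nn4)cc3F)ccnc2cc1OCCCN1CCN(C)CC1` awaits measurement; against compound 3 it carries methyl in place of hydrogen on an aromatic carbon. This is the same kind of change as that from compound 1 to compound 2, but the place now also reads meta to a methyl group, so the two changes are not the same. Because a 6.7-fold higher number from compound 1 to compound 2 (0.82 log units; beyond the scatter) weakened compound 2, a further weakening is expected, a 2.4-fold higher number from compound 3 to compound 4 (0.39 log units; beyond the scatter). Compound 4 is therefore estimated at 3500 nM in this assay, expected to fall between 1200 nM and 10000 nM.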

Compound 4, half-maximal inhibitory concentration: 2170 nM
Compound 4: the middle estimate sits 1.6-fold (0.21 log units) above what was measured, within the range that was stated.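

In this assay, going from 2-methylphenyl to 2,6-dimethylphenyl gives a 1.5-fold higher number from compound 3 to compound 4 (0.18 log units; within the scatter), so this methyl leaves no readable difference between the two compounds. The same change therefore does not carry over at the same size from one core to the other: the same change on two cores in this assay, a 6.7-fold higher number (0.82 log units; beyond the scatter) from compound 1 to compound 2 and a 1.5-fold higher number (0.18 log units; within the scatter) from compound 3 to compound 4, 4.4-fold (0.64 log units) apart, beyond the scatter of two such steps

These pairs differ both in the terminal amine, pyrrolidin-1-yl or 4-methylpiperazin-1-yl, and in whether a methyl already stands on the ring, and the two differences cannot be separated here, so what sets the steps apart is not shown.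

Open, as far as these compounds go, is how the 2,6-dimethylphenyl group reads with pyrrolidin-1-yl, and how the plain phenyl reads with 4-methylpiperazin-1-yl. Also open, from the compounds shown here alone, is whether a chlorine or a methoxy group in place of the methyl follows either step.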